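The compounds below may be only part of what the source reports. "The series", "measured", "known", "first", "only" and "open" are said of these compounds alone.

Measured compounds:
Compound 1 `Cc1cc(C)c(NC(=O)N(Cc2cccc(-c3nnn(C)n3)c2)C2CCCCCC2)c(C)c1` gives in a functional assay on a cell-free system (plasma) with sterol O-acyltransferase, Soat (Rattus norvegicus) as the target (on this read-out higher numbers stand for an effect only at larger amounts of compound and lower numbers for an effect already at smaller amounts), only a limit, < 1 mg/kg.
Compound 2 `CSc1cc(C)nc(SC)c1NC(=O)N(Cc1ccccc1)Cc1cccc(-c2cc[nH]n2)c1` gives in this assay 0.046 mg/kg.
Compound 3 `COc1ccc(CN(Cc2cccc(-c3cc[nH]n3)c2)C(=O)Nc2c(SC)cc(C)nc2SC)cc1` gives in this assay only a limit, < 0.1 mg/kg.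

Compound 3 thus stands at a limit of this assay, not at a number; two of the three values shown are limits (the limit of < 0.1 mg/kg in this assay, at which 1 of the 3 values shown sits, (the limit of < 1 mg/kg in this assay, at which 1 of the 3 values shown sits)), and the step that the limit leaves unreadable from compound 2 to compound 3 cannot be read for that reason. Compound 4 `COc1ccccc1CN(Cc1cccc(-c2cc[nH]n2)c1)C(=O)Nc1c(SC)cc(C)nc1SC` differs from compound 3 by 2-methoxyphenyl in place of 4-methoxyphenyl on a saturated chain carbon bound to an amide-type nitrogen. Going by the values given here, no measured step moves a group around this benzyl ring; the only step that touches it, a step that the limit leaves unreadable from compound 2 to compound 3, is unreadable. The expectation therefore rests on compound 2 with 0.046 mg/kg. It rests also on compound 3, which stands at a limit. The expected step that the limit leaves unreadable from compound 3 to compound 4 is none beyond the scatter. Compound 4 is estimated at 0.06 mg/kg, with a range of 0.02 mg/kg to 0.3 mg/kg.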

Compound 4, dose for half-maximal effect: > 0.1 mg/kg
Compound 4: no number, only a limit; the forecaster's own chance of this, stated with the estimate: 35%; middle value at least 1.6-fold (0.22 log units) from the limit.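

In this assay, going by these compounds alone, the methoxy of 2-methoxyphenyl gives the only readable step on this benzyl ring: an at least 2.1-fold higher number from compound 2 to compound 4 (0.33 log units; beyond the scatter). Moving the methoxy gives a number no lower from compound 3 to compound 4 (the limit leaves the size open). From the compounds shown here alone, compound 3 and compound 4 both stand at limits, so the direction shows but the size stays open.

The step from compound 2 to compound 3 cannot be read, which leaves open whether 4-methoxyphenyl differs from plain benzyl at all. Going by these compounds, how a chlorine or a hydroxyl on this ring would read also stays open.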